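A few compounds are considered here, and "the series" means these few. Any claim that something is new, unique, unknown or untested is made for them only; others in the source may bear on it.

In an ADME assay on THP-1 cells (Homo sapiens) for cytotoxicity (on this read-out lower numbers stand for higher toxicity in this test and higher numbers for lower toxicity in this test), compound 1 (`N#Cc1ccc(NC(=O)c2c(NC(=O)C(F)(F)F)sc3c2CCCCC3)cc1`) gives 9110 nM and compound 2 (`O=C(Nc1ccc(C(F)(F)F)cc1)c1c(NC(=O)C(F)(F)F)sc2c1CCCCC2`) gives 17200 nM, with a 1.9-fold higher number from compound 1 to compound 2 (0.28 log units; within the scatter). Compound 3 (`COc1ccc(CNC(=O)c2c(NC(=O)C(F)(F)F)sc3c2CCCCC3)cc1`) has only a limit, > 50000 nM. Compound 4 (`COc1ccccc1NC(=O)c1c(NC(=O)C(F)(F)F)sc2c1CCCCC2`) carries 2-methoxyphenyl in place of 4-methoxybenzyl on the amide-type nitrogen: 2-methoxyphenyl in place of 4-methoxybenzyl on an amide-type nitrogen. Among the compounds with values here, two measured steps bear on this change: an at least 5.4-fold higher number from compound 1 to compound 3 (0.73 log units; beyond the scatter), and an at least 2.9-fold higher number from compound 2 to compound 3 (0.46 log units; beyond the scatter). Both introduce 4-methoxybenzyl in place of a substituted phenyl, whereas compound 4 restores a substituted phenyl, so a modest move to a lower number in this assay is expected. The expected change is an at least 3.1-fold lower number from compound 3 to compound 4 (0.49 log units; beyond the scatter). For compound 4, the estimated value is 16000 nM, with an expected range of 6000 nM to 45000 nM.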

Compound 4, half-maximal cytotoxic concentration: > 50000 nM
Compound 4: a limit, no number (the forecaster's own chance of this, stated with the estimate: 15%); at least 3.1-fold (0.49 log units) between middle value and limit.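

In this assay, a phenyl group carried directly on the amide-type nitrogen does not by itself go with a lower number: 2-methoxyphenyl gives an at least 2.9-fold higher number from compound 2 to compound 4 (0.46 log units; beyond the scatter) and an at least 5.4-fold higher number from compound 1 to compound 4 (0.73 log units; beyond the scatter). The step between compound 3 and compound 4 cannot be read, since both values are limits: the limit of > 50000 nM in this assay, at which 2 of the 4 values shown sit.

The compounds shown leave open whether the methoxy group matters here, and an unsubstituted phenyl or an amine on that phenyl ring would bear on this. As far as these compounds go, how far the numbers extend past the limit also stays unknown.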